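Adding a second trifluoromethyl group to compound 2

This account rests on a few compounds, and the source may have more. Where it says the series, first, only, none or still open, it means among the compounds named here.

Values in a functional assay on VCaP cells (Homo sapiens) for antiproliferative activity, read by propidium iodide staining, with a stated time of 96 h; a higher number here means a weaker inhibitor, a lower number a stronger inhibitor:
compound 1 `CC(O)(CS(=O)(=O)c1ccc(C(F)(F)F)cc1)C(=O)Nc1ccc(S(F)(F)(F)(F)F)cc1`: 27700 nM
compound 2 `CC(O)(CS(=O)(=O)c1cccc(C(F)(F)F)c1)C(=O)Nc1ccc(S(F)(F)(F)(F)F)cc1`: 32000 nM

Compound 2 stands level with compound 1 on these numbers, and both are the only measured points so far. Among the measured compounds shown here, the single measured step, a 1.2-fold higher number from compound 1 to compound 2 (0.06 log units; within the scatter), moves the trifluoromethyl group to another position on the same aromatic ring and leaves the read-out within the scatter.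

The next compound is compound 3 `CC(O)(CS(=O)(=O)c1cc(C(F)(F)F)cc(C(F)(F)F)c1)C(=O)Nc1ccc(S(F)(F)(F)(F)F)cc1`. It differs from compound 2 as follows: trifluoromethyl in place of hydrogen on an aromatic carbon. In words, this is trifluoromethyl in place of hydrogen on an aromatic carbon, meta to a trifluoromethyl group.

For the measured compounds named here, no measured step adds a group to this ring, so the data offer no direct precedent for the change. Going by the values given here, the only guide is that the positional change gave a 1.2-fold higher number from compound 1 to compound 2 (0.06 log units; within the scatter). Going by these compounds, on that thin basis, no shift beyond the scatter is expected in this assay, though the uncertainty is wide and either direction remains open.

The estimated step is a 1.2-fold lower number from compound 2 to compound 3 (0.09 log units; within the scatter). Compound 3 is expected at 26000 nM, with an estimated range of 10000 nM to 60000 nM.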

Compound 3, half-maximal inhibitory concentration: 15800 nM
Estimate against measurement, compound 3: 1.6-fold (0.22 log units) above; measured number inside the range.
By their numbers in this assay, from the lowest: compounds 3, 1 and 2 (each within the scatter of the next, the first and the last beyond it).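

In this assay, among the compounds shown here, the added trifluoromethyl group gives a 2.0-fold lower number from compound 2 to compound 3 (0.31 log units; beyond the scatter), the only step so far that passes the scatter, while the earlier positional change gave only a 1.2-fold higher number from compound 1 to compound 2 (0.06 log units; within the scatter). A further substituent on this aromatic ring, placed meta to a trifluoromethyl group, therefore does not cost activity here and moves the number modestly towards stronger inhibition, although compound 3 still reads 15800 nM and the step rests on a single pair of compounds. Nothing available on these compounds accounts for the size or direction of this step.

Going by these compounds, it remains open whether this gain belongs to trifluoromethyl itself or to any group on that aromatic carbon, a question that a nitrile, a chlorine atom or a methoxy group at the same place would address. Also open, on these data alone, is whether the step holds with another group, such as a nitrile, in place of the pentafluorosulfanyl group on the amide side, since that group is the same in all three compounds.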